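This account rests on a few compounds, and the source may have more. Where it says the series, first, only, none or still open, it means among the compounds named here.

Among the measured compounds shown here, compound 2 `COc1cc(Oc2cccc(Nc3ccccc3)c2)cc(OC)c1CNCCNC(C)=O` gives 3960 nM in a functional assay on HT-29 cells (Homo sapiens) for inhibition, read by MTT assay, with a stated time of 72 h (on this read-out higher numbers stand for weaker inhibition and lower numbers for stronger inhibition), the highest of the two numbers measured so far; the nearest neighbour, compound 1 `COc1ccc(CNCc2c(OC)cc(Oc3cccc(Nc4ccccc4)c3)cc2OC)cc1`, gives 1890 nM in this assay. For the measured compounds named here, the only step between measured compounds is a 2.1-fold higher number from compound 1 to compound 2 (0.32 log units; beyond the scatter), where acetamidomethyl took the place of 4-methoxyphenyl. Compound 3 `COc1cc(Oc2cccc(Nc3ccccc3)c2)cc(OC)c1CNCc1ccc(Cl)cc1` differs from compound 2 by 4-chlorophenyl in place of acetamidomethyl on a saturated chain carbon bound to an amine nitrogen. This change largely reverses the earlier one: the acetamidomethyl group leaves again and an aromatic ring, now a 4-chlorophenyl rather than a 4-methoxyphenyl, takes its place. The step from compound 1 to compound 2 is the one that bears on it. Going by the values given here, no measured pair compares 4-chlorophenyl with 4-methoxyphenyl on this carbon, so the size of the return is uncertain. The step is expected to be modest and downward, about a 2.2-fold lower number from compound 2 to compound 3 (0.34 log units; beyond the scatter). Compound 3 is estimated at 1800 nM in this assay, with a range of 900 nM to 3600 nM.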

Compound 3, half-maximal inhibitory concentration: 3350 nM
For compound 3 the middle estimate is 1.9-fold (0.27 log units) below the measured one, and the stated range covers the measured number.
By their numbers in this assay, from the lowest: compounds 1, 3 and 2 (each within the scatter of the next, the first and the last beyond it).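

In this assay, 4-chlorophenyl in place of acetamidomethyl on the saturated chain carbon bound to an amine nitrogen gives a 1.2-fold lower number from compound 2 to compound 3 (0.07 log units; within the scatter), so this aromatic ring does not separate compound 3 from the amide-bearing chain. Chloro in place of methoxy on the aromatic carbon gives a 1.8-fold higher number from compound 1 to compound 3 (0.25 log units; within the scatter), which leaves compound 3 within the scatter of both neighbours, and only the step of a 2.1-fold higher number from compound 1 to compound 2 (0.32 log units; beyond the scatter) remains beyond it. Nothing at hand explains these results.

With only these three compounds, the data cannot show whether the aromatic ring or its substituent matters more at this position. From the compounds shown here alone, the effect of an unsubstituted phenyl, a carboxylic acid, a morpholine or a longer chain on this carbon remains open.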